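Lengthening a sulfur-linked chain without a change in toxicity

A few compounds are considered here, and "the series" means these few. Any claim that something is new, unique, unknown or untested is made for them only; others in the source may bear on it.

Compound 1 `CCCSc1nc(N)nc2c1ncn2/C=C1/CC1(CO)CO`: in an ADME assay on MOLT-3 cells (Homo sapiens) for cytotoxicity, with a stated time of 7 days (on this read-out lower numbers stand for higher toxicity in this test and higher numbers for lower toxicity in this test), compound 1 gives > 20000 nM, a limit of the test rather than a number.
Compound 2 `Nc1nc(N2CCCC2)c2ncn(/C=C3/CC3(CO)CO)c2n1`: in this assay compound 2 gives "not determined" (no result reported), that is, no result reported.
Compound 3 `CCCCCCCCSc1nc(N)nc2c1ncn2/C=C1/CC1(CO)CO`: in this assay compound 3 gives > 20000 nM, again a limit of the test.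

Compound 1 therefore stands only at a limit, and the same holds for compound 3. Compound 4 `CCCCCCSc1nc(N)nc2c1ncn2/C=C1/CC1(CO)CO` has not yet been measured; it differs from compound 1 by propyl in place of hydrogen on a saturated chain carbon, three bonds along the chain from a sulfur. Within the data shown here, the one measured step that bears on this change, a step that the two limits leave unreadable from compound 1 to compound 3, cannot be read in size because the limit of > 20000 nM in this assay, at which 2 of the 3 values shown sit, covers both of its ends. No step beyond the scatter is expected in this assay. For compound 4 the expected value is 40000 nM, within 15000 nM to 150000 nM. The step this estimate means, a step that the limit leaves unreadable from compound 1 to compound 4, is expected to stay within the scatter, most likely as another limit.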

Compound 4, half-maximal cytotoxic concentration: > 20000 nM
Compound 4 gave a limit, no number (the forecaster's own chance of this, stated with the estimate: 85%); the middle value lies beyond the limit too.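

No step can be read among compound 1, compound 3 and compound 4, because all three stop at a limit of the test rather than a number: the limit of > 20000 nM in this assay, at which 3 of the 4 values shown sit.

The compounds shown leave open whether chain length changes toxicity beyond that limit.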